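A few compounds are considered here, and "the series" means these few. Any claim that something is new, unique, unknown or untested is made for them only; others in the source may bear on it.

In a functional assay on A-375 cells (Homo sapiens) for antiproliferative activity, read by CCK-8 assay, with a stated time of 72 h (a lower number here means a stronger inhibitor, a higher number a weaker inhibitor), compound 1 `COc1ccc(SCc2ccc(C(=O)Nc3ccccc3N)cc2)cc1` gives 3010 nM and so stands level with its two relatives, since compound 2 `Nc1ccccc1NC(=O)c1ccc(CSc2cccc(F)c2)cc1` gives 3900 nM and compound 3 `Cc1ccc(SCc2ccc(C(=O)Nc3ccccc3N)cc2)cc1` gives 3700 nM with all three inside the usual scatter of one another. Compound 4 `COc1ccc(SCc2ccc(C(=O)Nc3ccccc3N)cc2)cc1OC` has not been measured yet. It differs from compound 1 by a single change methoxy in place of hydrogen on an aromatic carbon which amounts to methoxy in place of hydrogen on an aromatic carbon, ortho to a methoxy group and meta to a large group.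

For the measured compounds named here, no measured step adds a group at this place, so the evidence is indirect. Other changes on the same aromatic ring moved the number little. These are methyl in place of methoxy (a 1.2-fold higher number from compound 1 to compound 3 (0.09 log units; within the scatter)), 3-fluorophenyl in place of 4-methoxyphenyl on a sulfur (a 1.3-fold higher number from compound 1 to compound 2 (0.11 log units; within the scatter)) and 4-methylphenyl in place of 3-fluorophenyl on a sulfur (a 1.1-fold lower number from compound 2 to compound 3 (0.02 log units; within the scatter)). On the strength of these small steps, no step beyond the scatter is expected in this assay in either direction, although a new group at an untested place remains a real unknown. The expected step in this estimate is a 1.1-fold higher number from compound 1 to compound 4 (0.04 log units; within the scatter) and nothing larger is predicted. For compound 4 the estimated value is 3300 nM (expected range 1700 nM to 6500 nM).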

Compound 4, half-maximal inhibitory concentration: 4420 nM
Compound 4: the middle estimate sits 1.3-fold (0.13 log units) below what was measured, within the range that was stated.
By their numbers in this assay, from the lowest: compounds 1, 3, 2 and 4 (each within the scatter of the next).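

Adding a methoxy group ortho to a methoxy group and meta to a large group gives a direct reading for this change: in this assay it produces a 1.5-fold higher number from compound 1 to compound 4 (0.17 log units; within the scatter) and so leaves the number inside the usual variation between repeated measurements. The earlier steps shown here all replaced one group with another, whereas this step keeps the existing methoxy and adds a second one, which shows that a ring carrying both groups remains in the same range as compound 1. No measured property of these compounds bears on this result, so the data offer no explanation for the size of the step.

From the compounds shown here alone, it remains open whether a different group at this position, such as an amine, a carboxylic acid or a longer chain like butoxy, would also stay within the scatter or would produce a clear change. It is also unclear whether the new methoxy group would have the same small effect on a ring without the original methoxy group, as the compounds shown test it only alongside that neighbour.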